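Swapping the aryl on the ring nitrogen of compound 3

A few compounds are considered here, and "the series" means these few. Any claim that something is new, unique, unknown or untested is made for them only; others in the source may bear on it.

Measured so far in a functional assay on MDA-MB-231 cells (Homo sapiens) for inhibition, read by MTT assay, with a stated time of 72 h; on this read-out higher numbers stand for weaker inhibition and lower numbers for stronger inhibition:
- Compound 1, `O=C(CSc1nc(Nc2ccccc2)c2ccccc2n1)Nc1ccccc1Cl`, gives 24400 nM.
- Compound 2, `O=C(CSc1nc(Nc2ccccc2)c2ccccc2n1)Nc1cccc(F)c1`, gives only a limit of the assay, > 50000 nM.
- Compound 3, `C=CC(=O)Nc1cccc(NC(=O)CSc2nc(Nc3cccc(F)c3)c3ccccc3n2)c1`, gives 8160 nM.

Among the two numbers, compound 3 gives the lowest, with compound 1 the nearest, beyond the scatter; the value for compound 2 is a limit, not a number (the limit of > 50000 nM in this assay, at which 1 of the 3 values shown sits). Going by the values given here, the only measured step, an at least 2.0-fold higher number from compound 1 to compound 2 (0.31 log units; beyond the scatter), concerns the aryl on the amide-type nitrogen.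

Compound 4, `C=CC(=O)Nc1cccc(NC(=O)CSc2nc(Nc3cc(OC)c(OC)c(OC)c3)c3ccccc3n2)c1`, differs from compound 3 elsewhere: 3,4,5-trimethoxyphenyl in place of 3-fluorophenyl on a nitrogen on an aromatic ring. Among the compounds with values here, no measured step touches this nitrogen, so no step bears on the change, and its direction cannot be read from the data. A change near the scatter, with room either way, is therefore expected, a 1.4-fold lower number from compound 3 to compound 4 (0.13 log units; within the scatter). In this assay compound 4 is estimated at 6000 nM, within a range from 1500 nM to 25000 nM.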

Compound 4, half-maximal inhibitory concentration: > 50000 nM
Compound 4 ended at the assay's limit; the forecaster's own chance of this, stated with the estimate: 10%; at least 8.3-fold (0.92 log units) between middle value and limit.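

In this assay compound 4 gives > 50000 nM, which is a limit of the assay and not a number. Going by these compounds alone, putting 3,4,5-trimethoxyphenyl in place of 3-fluorophenyl on this nitrogen gives an at least 6.1-fold higher number from compound 3 to compound 4 (0.78 log units; beyond the scatter), so the aryl here, which no earlier step touched, clearly affects the read-out, and this position does not accept every aryl equally. Compound 4 now shares its limit with compound 2: the limit of > 50000 nM in this assay, at which 2 of the 4 values shown sit.

The compounds shown cannot separate the effect of losing the fluorine from that of adding the methoxy groups, or say whether one methoxy group would do the same as three. From the compounds shown here alone, how the read-out would respond to an aryl carrying an amine or a carboxylic acid, or to an ethyl chain in place of the aryl, also remains open.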